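The source may hold more compounds than are shown below. What is called first, only, known or untested is meant among the compounds shown, and "the series" means these compounds.

Measured compounds:
- compound 1, `CCN(Cc1ccccc1)c1cccc(C(=O)N2CCc3ccc(OS(N)(=O)=O)cc3C2)c1`: 69%
- compound 2, `NS(=O)(=O)Oc1ccc2c(c1)CN(C(=O)c1cccc(N(Cc3ccccc3)Cc3ccco3)c1)CC2`: 90.5%
- compound 3, `CN(C)CCN(Cc1ccccc1)c1cccc(C(=O)N2CCc3ccc(OS(N)(=O)=O)cc3C2)c1`: 28.6%

In an assay on HEK293 cells for inhibition of Steryl-sulfatase (Homo sapiens), tested at 1 uM (on this read-out lower numbers stand for a weaker effect and higher numbers for a stronger effect at the one concentration tested), compound 1 gives 69%, the second highest of the three numbers. The step of a number 21.5 percentage points higher from compound 1 to compound 2 (beyond the scatter) lifts it, while the step of a number 40.4 percentage points lower from compound 1 to compound 3 (beyond the scatter) lowers it, and the step of a number 61.9 percentage points lower from compound 2 to compound 3 (beyond the scatter) spans the whole set. All three measured compounds keep the benzyl group on the nitrogen and vary only the second chain on that nitrogen.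

Compound 4, `NS(=O)(=O)Oc1ccc2c(c1)CN(C(=O)c1cccc(N3CCc4ccccc4C3)c1)CC2`, is not yet measured in this assay. It differs from compound 1 in one place: 1,2,3,4-tetrahydroisoquinolin-2-yl in place of benzyl(ethyl)amino on an aromatic carbon. Here the benzyl(ethyl)amino group is exchanged as a whole for a ring-fused amine, so none of the measured steps covers this kind of change directly; they show only that altering the chains on this nitrogen can move the number substantially in either direction. Since an aromatic ring and the nitrogen are retained, the effect is expected to stay near that of compound 1, with wide uncertainty.

Compound 4 is therefore estimated at 60%, with a range from 30% to 85%. For compound 4 this corresponds to an expected step of a number 9 percentage points lower from compound 1 to compound 4 (within the scatter).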

Compound 4, a percentage reported as inhibition, at one concentration (the size of the read-out at that concentration, not a potency): 50.2%
For compound 4 the middle estimate is 9.8 percentage points above the measured one; low and high end bracket the measured number.
By their numbers in this assay, from the lowest: compound 3; then compound 4; then compound 1; then compound 2.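

In this assay, closing the two chains on the nitrogen into a 1,2,3,4-tetrahydroisoquinolin-2-yl ring gives a number 18.8 percentage points lower from compound 1 to compound 4 (beyond the scatter). The group that enters has the same count of heavy atoms, hydrogen-bond donors and hydrogen-bond acceptors as benzyl(ethyl)amino, so on this aromatic carbon a new arrangement of the same kinds of atoms is enough to move the number beyond the scatter. Nothing measured on these compounds explains this drop.

The compounds shown leave open whether the aromatic ring of the entering group matters, which a piperidin-1-yl or morpholin-4-yl group on the same aromatic carbon would test. They also leave open whether a methoxy group on the 1,2,3,4-tetrahydroisoquinolin-2-yl ring would raise or lower the number.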